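The compounds below may be only part of what the source reports. "The series", "measured", "known", "first", "only" and "open" are said of these compounds alone.

In a functional assay on A549 cells (Homo sapiens) for antiproliferative activity (a lower number here means that less compound is needed, a higher number that more compound is needed for the effect), compound 1 `CCCCCC/C(=N\OCCCCC)c1cc(OC)c2c(c1OC)C(=O)C=CC2=O` gives > 10 ug/mL, which is a limit of the assay rather than a measured number. Compound 2 `CCCCCCCO/N=C/c1cc(OC)c2c(c1OC)C(=O)C=CC2=O` in this assay gives > 10 ug/mL, again a limit. Compound 3 `CO/N=C/c1cc(OC)c2c(c1OC)C(=O)C=CC2=O` in this assay gives > 10 ug/mL, also a limit and not a number. Within the data shown here, compound 3 therefore stands where every value shown stands, at the limit described by the limit of > 10 ug/mL in this assay, at which 3 of the 3 values shown sit, so no compound in this set can be ranked against another.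

Between compound 2 and compound 3 there is one structural change, hydrogen in place of hexyl on a saturated chain carbon bound to an oxygen on an unsaturated carbon, and the step that the two limits leave unreadable from compound 2 to compound 3 cannot be sized because both of its ends sit at the limit of > 10 ug/mL in this assay, at which 3 of the 3 values shown sit.

Compound 4 `CCCO/N=C/c1cc(OC)c2c(c1OC)C(=O)C=CC2=O` differs from compound 3 in this way: ethyl in place of hydrogen on a saturated chain carbon bound to an oxygen on an unsaturated carbon. Among the measured compounds shown here, the only step that bears on this change is the one from hexyl to hydrogen, and it gives no readable size, so no direction can be drawn from it. Compound 4 is expected to behave like the rest of the series, with a step that the limit leaves unreadable from compound 3 to compound 4 that stays within the scatter. For compound 4 the estimate in this assay is 15 ug/mL, expected to fall between 5 ug/mL and 50 ug/mL, most likely reported again only as a limit.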

Compound 4, concentration for half-maximal effect: > 10 ug/mL
Compound 4 gave a limit, no number; the forecaster's own chance of this, stated with the estimate: 80%; the middle value does not contradict the limit.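

In this assay compound 4 gives > 10 ug/mL, a limit and not a number. No step linking compound 4 to compound 2 or compound 3 can be read, because all the values share one limit: the limit of > 10 ug/mL in this assay, at which 4 of the 4 values shown sit.

The compounds shown leave open whether the length of the chain on the oxygen affects the result in this assay at all.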